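Azetidine oxadiazoles: swapping the carbonyl substituent in compound 2

A few compounds are considered here, and "the series" means these few. Any claim that something is new, unique, unknown or untested is made for them only; others in the source may bear on it.

Measured so far:
- compound 1 `O=C(c1ccccc1F)N1CC[C@H]1c1nc(-c2cccc(F)c2)no1`: 920 nM
- compound 2 `O=C(N1CCC(F)CC1)N1CC(c2nc(-c3cccc(Cl)c3)no2)C1`: > 10000 nM
- compound 3 `Cc1ccc(S(=O)(=O)N2CC(c3nc(-c4cccc(Cl)c4)no3)C2)cc1`: 920 nM

In an assay on HEK293 cells for negative allosteric modulation of metabotropic glutamate receptor 5 (Homo sapiens), read by FLIPR (on this read-out higher numbers stand for weaker inhibition and lower numbers for stronger inhibition), compound 1 gives 920 nM and compound 3 gives 920 nM, two values within the scatter of each other. For compound 2 this assay reports only a limit, > 10000 nM, so no number stands behind it (the limit of > 10000 nM in this assay, at which 1 of the 3 values shown sits). The unmeasured compound 4 `O=C(c1ccccc1F)N1CC(c2nc(-c3cccc(Cl)c3)no2)C1` comes from compound 2 through the change (2-fluorophenyl in place of 4-fluoropiperidin-1-yl on a carbonyl carbon). Compound 1 also carries a 2-fluorophenyl on a carbonyl carbon, and its value shows that this arrangement can sit well inside the measurable range. From the limit of compound 2, the expected step from compound 2 to compound 4 is estimated as a clear gain beyond the scatter, an at least 12-fold lower number from compound 2 to compound 4 (1.09 log units; beyond the scatter), toward stronger inhibition. Compound 4 is therefore expected to come in at about 800 nM, estimated between 200 nM and 4000 nM in this assay.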

Compound 4, half-maximal inhibitory concentration: 670 nM
Beside the measured number, compound 4's estimate is 1.2-fold (0.08 log units) above it; measured number inside the range.
By their numbers in this assay, from the lowest: compounds 4, 1 and 3 (each within the scatter of the next). At a limit, above all of these: compound 2.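

On the carbonyl carbon of the shared core, 2-fluorophenyl in place of 4-fluoropiperidin-1-yl moves the series from a limit into the measurable range of this assay, with an at least 14-fold lower number from compound 2 to compound 4 (1.17 log units; beyond the scatter). The value of compound 2 is a limit and not a number, so this step gives only a minimum size: the limit of > 10000 nM in this assay, at which 1 of the 4 values shown sits. The two groups match in the counts of heavy atoms, donors and acceptors. The entering group carries an aromatic ring of carbon only, and the leaving group carries a non-aromatic ring with a hetero atom. The data assign no cause to this step.

Open, on these data alone, is how an unsubstituted phenyl or a pyridyl ring would read on this carbonyl carbon, which would separate the fluorine from the ring itself. Equally open, as far as these compounds go, is whether an open-chain amine such as dimethylamino there would stay at a limit, as compound 2 does.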